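Shortening the alkyl chain on the shared core

This account rests on a few compounds, and the source may have more. Where it says the series, first, only, none or still open, it means among the compounds named here.

Three compounds on one core have numbers in a functional assay on MCF7 cells (Homo sapiens) for cytotoxicity, read by MTT assay, with a stated time of 72 h; on this read-out higher numbers stand for weaker inhibition and lower numbers for stronger inhibition. Compound 1 `CC(C)(C)c1nnc2nnc(N3CCCC3)nn12` gives 55000 nM. Compound 2 `CCCCCc1nnc2nnc(N3CCCC3)nn12` gives 42900 nM. Compound 3 `Clc1ccc(-c2nnc3nnc(N4CCCC4)nn23)c(Cl)c1` gives 19600 nM. On these three numbers compound 2 stands second highest: the step of a 1.3-fold lower number from compound 1 to compound 2 (0.11 log units; within the scatter) lies within the scatter, so compound 1 and compound 2 cannot be separated, while compound 3 shows the lower number of the set, beyond the scatter from compound 2.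

Compound 4 `CCc1nnc2nnc(N3CCCC3)nn12` has not yet been measured. Relative to compound 2 the change is hydrogen in place of propyl on a saturated chain carbon, two bonds along the chain from an aromatic carbon. For the measured compounds named here, the only measured step that touches an alkyl group on the core is a 1.3-fold lower number from compound 1 to compound 2 (0.11 log units; within the scatter), and it stayed within the scatter; no measured step shortens a chain, and no measured compound carries a group as small as ethyl here. Going by the values given here, nothing among the measured compounds points to a move beyond the scatter, so the step of a 1.2-fold higher number from compound 2 to compound 4 (0.07 log units; within the scatter) is expected to be small, with its direction uncertain and a slightly higher number somewhat more likely than a lower one. Compound 4 is therefore estimated at 50000 nM in this assay, with a range from 25000 nM to 120000 nM.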

Compound 4, half-maximal inhibitory concentration: 47000 nM
For compound 4 the middle estimate is 1.1-fold (0.03 log units) above the measured one; the range from low to high includes it.
By their numbers in this assay, from the lowest: compound 3; then compounds 2, 4 and 1 (each within the scatter of the next).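

In this assay the chain at this position goes from pentyl to ethyl with a 1.1-fold higher number from compound 2 to compound 4 (0.04 log units; within the scatter) and stays inside the scatter, so loss of propyl from the chain, two bonds along from an aromatic carbon, leaves no readable mark on the number. Adding a 1.2-fold lower number from compound 1 to compound 4 (0.07 log units; within the scatter) to this gives three alkyl groups (tert-butyl, pentyl and ethyl) that cannot be separated from one another, where earlier only one such pair could be compared, and across compounds 1, 2 and 4 neither chain length nor branching sorts the numbers, while the lowest number of the set stays with compound 3 at 19600 nM in this series. Nothing in the data shown accounts for these numbers staying together.

Still open, as far as these compounds go, is whether any alkyl group at this position can move the number beyond the scatter, which methyl or a much longer chain such as decyl would test. Also open, from the compounds shown here alone, is whether a chain ending in an amine or a carboxylic acid, or an unsubstituted phenyl compared with the dichlorophenyl group of compound 3, would read differently on the shared core.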